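The source may report more compounds than this note shows. Statements on the series, on what has been measured and on what is new or still open speak of the compounds shown alone.

Going by the values given here, compound 2 `Cc1ccc(S(=O)(=O)CCO)cc1C#Cc1cc(Cl)ccc1OCC(=O)O` stands with the highest number of the two measured so far: in an assay on CHO cells for displacement of a labelled ligand from prostaglandin D2 receptor 2 (Homo sapiens), read by scintillation counting (on this read-out higher numbers stand for weaker inhibition and lower numbers for stronger inhibition), compound 2 gives 19 nM, while compound 1 `CC(C)Cc1ccncc1C#Cc1cc(Cl)ccc1OCC(=O)O` gives 4.9 nM, a gap beyond the scatter. Compound 3 `Cc1ccc(S(=O)(=O)N(C)CC(C)C)cc1C#Cc1cc(Cl)ccc1OCC(=O)O` differs from compound 2 in one place: isobutyl(methyl)amino in place of 2-hydroxyethyl on a sulfonyl sulfur. Among the compounds with values here, no measured pair shows this change, so its size is open. Compound 3 is expected to move a modest step toward a lower number, a 1.9-fold lower number from compound 2 to compound 3 (0.28 log units; within the scatter), since compound 1, which also carries an isobutyl chain, gives 4.9 nM. Compound 3 is therefore estimated at 10 nM, with a range from 3 nM to 40 nM.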

Compound 3, inhibition constant: 4.2 nM
Beside the measured number, compound 3's estimate is 2.4-fold (0.38 log units) above it; the range from low to high includes it.
By their numbers in this assay, from the lowest: compounds 3 and 1 (each within the scatter of the next); then compound 2.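

Isobutyl(methyl)amino in place of 2-hydroxyethyl on a sulfonyl sulfur brings a 4.5-fold lower number from compound 2 to compound 3 (0.66 log units; beyond the scatter) in this assay and so shows that the group on this sulfur can shift the number beyond the scatter. The step also shows that a hydroxyl-free group with no hydrogen-bond donors is accepted here. Size and hydrogen-bond count change together in this swap, and the single step does not separate them. A dimethylamino group or a morpholine ring on the same sulfur would show whether the isobutyl chain itself matters. The reason for the step stays open, as no measurement at hand bears on it.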